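The source may report more compounds than this note shows. Statements on the series, on what has been measured and on what is new or still open speak of the compounds shown alone.

Measured compounds in a functional assay on OVCAR-4 cells (Homo sapiens) for antiproliferative activity, with a stated time of 48 h; on this read-out lower numbers stand for stronger inhibition of growth and higher numbers for weaker inhibition of growth:

compound 1 `Cc1cc(O)c(C2=NN(c3ccc(S(N)(=O)=O)cc3)C(c3ccccc3Cl)C2)cc1Cl` — 2730 nM
compound 2 `Cc1cc(O)c(C2=NN(c3ccc(S(N)(=O)=O)cc3)C(/C=C/c3ccccc3)C2)cc1Cl` — 3740 nM

Among the measured compounds shown here, compound 2 gives the highest of the two numbers in this assay, with compound 1 the only neighbour; the step of a 1.4-fold higher number from compound 1 to compound 2 (0.14 log units; within the scatter) is within the scatter, so the two values cannot be ordered.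

Compound 3 `COc1ccc(C2CC(c3cc(Cl)c(C)cc3O)=NN2c2ccc(S(N)(=O)=O)cc2)c(OC)c1OC` differs from compound 2 in one place: 2,3,4-trimethoxyphenyl in place of 2-phenylethenyl on a saturated ring carbon. For the measured compounds named here, the only measured step on this ring carbon, a 1.4-fold higher number from compound 1 to compound 2 (0.14 log units; within the scatter), exchanged one aryl-type substituent for another without moving the number beyond the scatter. Going by the values given here, no measured step covers a trimethoxyphenyl group, so the direction of any effect cannot be read from the data; the single precedent on this carbon argues for a step of no more than the scatter.

On that basis compound 3 is expected near 3000 nM in this assay, in a range from 1000 nM to 9000 nM. The estimated step of a 1.2-fold lower number from compound 2 to compound 3 (0.10 log units; within the scatter) is therefore expected to stay within the scatter.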

Compound 3, concentration for 50% growth inhibition: 3470 nM
Compound 3: middle estimate off by 1.2-fold (0.06 log units), on the low side, and the stated range covers the measured number.
By their numbers in this assay, from the lowest: compounds 1, 3 and 2 (each within the scatter of the next).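

In this assay, the saturated ring carbon now also carries a substituent with oxygen atoms and hydrogen-bond acceptors, which the 2-phenylethenyl group lacks, and the result is a 1.1-fold lower number from compound 2 to compound 3 (0.03 log units; within the scatter); against the 2-chlorophenyl group the change gives a 1.3-fold higher number from compound 1 to compound 3 (0.10 log units; within the scatter). The three groups compared here, 2-chlorophenyl, 2-phenylethenyl and 2,3,4-trimethoxyphenyl, therefore cannot be ordered at this position, despite their differences in heavy atoms and acceptors. Nothing available accounts for this result.

Going by these compounds, each of these substituents contains a six-membered aromatic ring, so whether an amine, a carboxylic acid or a longer alkyl chain on this carbon would move the number beyond the scatter remains open. All three compounds also share the 5-chloro-2-hydroxy-4-methylphenyl and 4-sulfamoylphenyl groups, leaving the effect of changes at those places unknown.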